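Solubility at the assay limit and a trifluoromethyl analogue

The source may hold more compounds than are shown below. What is called first, only, known or untested is meant among the compounds shown, and "the series" means these compounds.

For the measured compounds named here, compound 3 `CNC(=O)c1cc(Oc2ccc3nc(Nc4ccccc4Br)ncc3c2)ccn1` is one of three compounds measured in a physicochemical assay for solubility, at pH 7; a higher number here means a more soluble compound, a lower number a less soluble compound. In this assay compound 3 gives < 1000 nM, which is a limit of the assay and not a number. Compound 1 `CNC(=O)c1cc(Oc2ccc3nc(Nc4ccccc4)ncc3c2)ccn1` likewise gives < 1000 nM, a limit. Compound 2 `CNC(=O)c1cc(Oc2ccc3nc(Nc4cccc(C(C)(C)C)c4)ccc3c2)ccn1` gives < 1000 nM, also a limit. In short, (the limit of < 1000 nM in this assay, at which 3 of the 3 values shown sit). The step that the two limits leave unreadable from compound 1 to compound 3 is therefore unreadable. Compound 4 `CNC(=O)c1cc(Oc2ccc3nc(Nc4cccc(C(F)(F)F)c4)ncc3c2)ccn1` differs from compound 3 by 3-(trifluoromethyl)phenyl in place of 2-bromophenyl on a nitrogen on an aromatic ring. Going by the values given here, no measured step bears on this change, and every measured compound sits at the limit. The step that the limit leaves unreadable from compound 3 to compound 4 is expected to lie within the scatter. Compound 4 is accordingly estimated at 500 nM, in a range from 100 nM to 1500 nM, most likely reported again as a limit.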

Compound 4, solubility: < 1000 nM
Compound 4: a limit, no number; the forecaster's own chance of this, stated with the estimate: 80%; the middle value does not contradict the limit.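

In this assay, compound 4 gives a limit and not a number, so neither step, from compound 1 or from compound 3 to compound 4, can be read: the limit of < 1000 nM in this assay, at which 4 of the 4 values shown sit.

The compounds shown leave open how compound 1, compound 2, compound 3 and compound 4 actually compare in this assay.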